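The source may hold more compounds than are shown below. What is called first, only, known or untested is meant among the compounds shown, and "the series" means these compounds.

In an ADME assay on BHK-21 cells (Mesocricetus auratus) for cytotoxicity, read by MTT assay, with a stated time of 72 h (on this read-out higher numbers stand for lower toxicity in this test and lower numbers for higher toxicity in this test), compound 1 (`Brc1ccc(NCc2cn(-c3ccccc3)nc2-c2ccccc2)cc1`) gives > 100000 nM as a limit of the assay and not a number. Among the compounds with values here, compound 2 (`Cc1ccc(NCc2cn(-c3ccccc3)nc2-c2ccc(C(F)(F)F)cc2)cc1`) gives 88000 nM as the only actual number so far. Compound 3 (`Cc1ccc(NCc2cn(-c3ccccc3)nc2-c2ccccc2)cc1`) has hydrogen in place of trifluoromethyl on an aromatic carbon, para to a large group (hydrogen in place of trifluoromethyl on an aromatic carbon). Within the data shown here, no measured step bears on this change. The expected outcome (a 1.0-fold higher number from compound 2 to compound 3 (0.01 log units; within the scatter)) is a step no larger than the scatter, with no direction favoured. Compound 3 is estimated in this assay at 90000 nM (expected range 40000 nM to 100000 nM).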

Compound 3, half-maximal cytotoxic concentration: > 100000 nM
Compound 3: a limit, no number; the forecaster's own chance of this, stated with the estimate: 50%; middle value at least 1.1-fold (0.04 log units) from the limit.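

Within the data shown here, at this position, hydrogen in place of trifluoromethyl now gives the first readable step in this assay: an at least 1.1-fold higher number from compound 2 to compound 3 (0.05 log units; that floor lies within the scatter). Compound 3 gives > 100000 nM, which is a limit of the assay and not a number. The step between compound 1 and compound 3 cannot be read, and the values gather at one end of the scale: the limit of > 100000 nM in this assay, at which 2 of the 3 values shown sit.

From the compounds shown here alone, whether an amine or a carboxylic acid on this aromatic carbon would give a number in this assay remains open.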